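This account rests on a few compounds, and the source may have more. Where it says the series, first, only, none or still open, it means among the compounds named here.

Measured compounds:
Compound 1 `O=c1c(Cc2coc3cccc(OCC4CCCCC4)c3c2=O)coc2ccccc12` gives 3530 nM in a functional assay on NUGC-3 cells (Homo sapiens) for antiproliferative activity, read by XTT assay; a lower number here means a stronger inhibitor, a higher number a weaker inhibitor.
Compound 2 `O=c1c(Cc2coc3cccc(OCC4CCCCC4)c3c2=O)coc2cc(Cl)ccc12` gives only a limit of this assay, > 10000 nM.
Compound 3 `COc1ccc2c(=O)c(Cc3coc4cccc(OCC5CCCCC5)c4c3=O)coc2c1` gives 1440 nM.

Compound 3 holds the lowest of the two numbers in this assay; the nearest is compound 1, separated by the step of a 2.5-fold lower number from compound 1 to compound 3 (0.39 log units; beyond the scatter). Compound 2 sits at the assay limit (the limit of > 10000 nM in this assay, at which 1 of the 3 values shown sits), so its distance from compound 3 is known only as an at least 6.9-fold lower number from compound 2 to compound 3 (0.84 log units; beyond the scatter).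

The next compound, compound 4 `Cc1ccc2c(=O)c(Cc3coc4cccc(OCC5CCCCC5)c4c3=O)coc2c1`, differs from compound 3 by methyl in place of methoxy on an aromatic carbon. Among the measured compounds shown here, three measured steps bear on this position. Adding methoxy to hydrogen gave a 2.5-fold lower number from compound 1 to compound 3 (0.39 log units; beyond the scatter); adding chloro gave an at least 2.8-fold higher number from compound 1 to compound 2 (0.45 log units; beyond the scatter); and chloro to methoxy gave an at least 6.9-fold lower number from compound 2 to compound 3 (0.84 log units; beyond the scatter). Methyl carries neither the hydrogen-bond acceptor counted for methoxy nor the chloro of compound 2, so compound 4 is expected to fall back toward compound 1, a modest upward step in this assay that may not clear the scatter. The expected step is a 1.7-fold higher number from compound 3 to compound 4 (0.24 log units; within the scatter). Compound 4 is therefore estimated at 2500 nM, between 1000 nM and 7000 nM.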

Compound 4, half-maximal inhibitory concentration: 2150 nM
The estimate for compound 4 lay 1.2-fold (0.07 log units) above the measured number; measured number inside the range.
By their numbers in this assay, from the lowest: compounds 3, 4 and 1 (each within the scatter of the next, the first and the last beyond it). At a limit, above all of these: compound 2.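

In this assay, methyl at this position cannot be told apart from methoxy: a 1.5-fold higher number from compound 3 to compound 4 (0.17 log units; within the scatter). Nor can it be told apart from hydrogen: a 1.6-fold lower number from compound 1 to compound 4 (0.22 log units; within the scatter). Compound 4 thus sits within the scatter of both compounds, so the methoxy oxygen, with its hydrogen-bond acceptor, is not shown to be required, although the step between hydrogen and methoxy alone clears the scatter. Methyl and chloro do separate, an at least 4.6-fold lower number from compound 2 to compound 4 (0.66 log units; beyond the scatter), but this step is only a bound, as the value of compound 2 is a limit of the assay: the limit of > 10000 nM in this assay, at which 1 of the 4 values shown sits.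

Going by these compounds, the true size of the gap to chloro stays open, since compound 2 gives no number. Also open, on these data alone, is whether ethoxy, an amine or a carboxylic acid at this position would separate from methyl and methoxy, or would fall with chloro.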